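A few compounds are considered here, and "the series" means these few. Any claim that something is new, unique, unknown or untested is made for them only; others in the source may bear on it.

Measured in a functional assay (aorta) with Rattus norvegicus as the target; a lower number here means a stronger inhibitor, a higher number a weaker inhibitor:
compound 1 `CC1(C)Oc2ccc(C#N)cc2[C@@H](/N=C(\NC#N)Nc2ccc(Cl)cc2)[C@@H]1O`, 1800 nM;
compound 2 `CC1(C)Oc2ccc(C(=O)Cc3ccccc3)cc2[C@@H](/N=C(\NC#N)Nc2ccc(Cl)cc2)[C@@H]1O`, 6800 nM;
compound 3 `CC1(C)Oc2ccc(S(=O)(=O)N3CCCCC3)cc2[C@@H](/N=C(\NC#N)Nc2ccc(Cl)cc2)[C@@H]1O`, 1900 nM.

Compound 3 stands second highest of the three numbers in this assay: its number sits beside that of compound 1, a gap within the scatter (a 1.1-fold higher number from compound 1 to compound 3 (0.02 log units; within the scatter)), while compound 2 lies furthest from it (a 3.6-fold lower number from compound 2 to compound 3 (0.55 log units; beyond the scatter)). Compound 4 `C[C@@H]1CCC[C@H](C)N1S(=O)(=O)c1ccc2c(c1)[C@@H](/N=C(\NC#N)Nc1ccc(Cl)cc1)[C@H](O)C(C)(C)O2` differs from compound 3 by 2,6-dimethylpiperidin-1-yl in place of piperidin-1-yl on a sulfonyl sulfur. Within the data shown here, no measured step varies the ring on the sulfonyl sulfur; the steps that exist replace the whole group on the aromatic carbon, and even these moved the number only modestly, as a 3.8-fold higher number from compound 1 to compound 2 (0.58 log units; beyond the scatter) shows. For compound 4 the expected step is therefore small, in either direction, a 1.1-fold higher number from compound 3 to compound 4 (0.02 log units; within the scatter). Compound 4 is expected to give 2000 nM in this assay, between 700 nM and 6000 nM.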

Compound 4, half-maximal inhibitory concentration: 500 nM
Compound 4: the middle estimate sits 4.0-fold (0.60 log units) above what was measured, outside the stated range (below it).
By their numbers in this assay, from the lowest: compound 4; then compounds 1 and 3 (each within the scatter of the next); then compound 2.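

In this assay, the ring on the sulfonyl sulfur proves to matter: 2,6-dimethylpiperidin-1-yl in place of piperidin-1-yl gives a 3.8-fold lower number from compound 3 to compound 4 (0.58 log units; beyond the scatter). The sulfonyl group, level with cyano as (piperidin-1-yl)sulfonyl, now separates from it, a 3.6-fold lower number from compound 1 to compound 4 (0.56 log units; beyond the scatter), and the gap to benzylcarbonyl widens to a 14-fold lower number from compound 2 to compound 4 (1.13 log units; beyond the scatter), leaving compound 4 with the lowest number of the four. Nothing shown accounts for this step. On these data alone, whether a single methyl on the piperidine ring would give the same step remains open. So does the outcome with a morpholin-4-yl ring on the sulfonyl sulfur, or with the opposite arrangement at the two defined stereocentres.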